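Fluoro in place of hydrogen, with a chloro step as guide

The source may report more compounds than this note shows. Statements on the series, on what has been measured and on what is new or still open speak of the compounds shown alone.

Values so far in a functional assay on a cell-free system (Platelet, plasma, Homo sapiens) for inhibition (on this read-out lower numbers stand for stronger inhibition and higher numbers for weaker inhibition), are:
- compound 1 `O=C(NC[C@H](NS(=O)(=O)c1cccs1)C(=O)O)c1ccc(N2CCC[C@H](NC3=NCCCN3)C2)cc1` gives 99 nM here
- compound 2 `O=C(NC[C@H](NS(=O)(=O)c1ccccc1)C(=O)O)c1ccc(N2CCC(NC3=NCCCN3)CC2)c(Cl)c1` gives 90 nM here
- compound 3 `O=C(NC[C@H](NS(=O)(=O)c1ccccc1)C(=O)O)c1ccc(N2CCC(NC3=NCCCN3)CC2)cc1` gives 290 nM here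

Compound 3 has the highest number of the three, which makes it the weakest inhibitor among them. Compound 4 `O=C(NC[C@H](NS(=O)(=O)c1ccccc1)C(=O)O)c1ccc(N2CCC(NC3=NCCCN3)CC2)c(F)c1` differs from it by one change fluoro in place of hydrogen on an aromatic carbon with fluoro in place of hydrogen on an aromatic carbon, ortho to a large group and meta to a large group. Among the compounds with values here, one measured step bears on this, with chloro at that same place: a 3.2-fold higher number from compound 2 to compound 3 (0.51 log units; beyond the scatter) is a modest step. Within the data shown here, no measured compound carries fluoro, so only part of that step is expected to carry over, as a lower number. The expected step is a 1.7-fold lower number from compound 3 to compound 4 (0.23 log units; within the scatter) in this assay as a rough guide. Compound 4 is estimated at 170 nM with 80 nM to 340 nM as its expected range.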

Compound 4, half-maximal inhibitory concentration in the Platelet assay: 37 nM
For compound 4 the middle estimate is 4.6-fold (0.66 log units) above the measured one; measured number below the stated range.
By their numbers in the Platelet assay, from the lowest: compound 4; then compounds 2 and 1 (each within the scatter of the next); then compound 3.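

In the Platelet assay, fluoro on this aromatic carbon gives a 7.8-fold lower number from compound 3 to compound 4 (0.89 log units; beyond the scatter), and fluoro in place of chloro at the same place gives a 2.4-fold lower number from compound 2 to compound 4 (0.39 log units; beyond the scatter), so here fluoro outdoes chloro. In a physicochemical assay for solubility (a lower number here means a less soluble compound, a higher number a more soluble compound), compound 3 gives < 100 ug/mL, which is a limit of the assay and not a number. In the physicochemical assay compound 4 gives 600 ug/mL. In the physicochemical assay the same change goes with an at least 6.0-fold higher number from compound 3 to compound 4 (0.77 log units; beyond the scatter), a step that starts from that limit: the limit of < 100 ug/mL in the physicochemical assay, at which 1 of the 2 values shown sits.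

Open, going by these compounds, is how a methyl or a methoxy group would fare at this place, and whether fluoro acts alike on the core of compound 1.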